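The source may hold more compounds than are shown below. What is called first, only, known or untested is meant among the compounds shown, and "the series" means these compounds.

Compound 1 `COc1cc(-c2cc(C(=O)/C=C/c3ccc(Cl)cc3)nc3cc(-c4ccccc4)nn23)cc(OC)c1OC` gives 19500 nM in a functional assay on DU-145 cells (Homo sapiens) for antiproliferative activity, read by MTT assay, with a stated time of 24 h (on this read-out higher numbers stand for weaker inhibition and lower numbers for stronger inhibition), the lowest of the three numbers shown, though all three lie within the scatter of one another. Compound 2 `COc1cc(-c2cc(/C=C/C(=O)c3ccc(C)cc3)nc3cc(-c4ccccc4)nn23)cc(OC)c1OC` gives 27100 nM in this assay, and compound 3 `COc1cc(-c2cc(/C=C/C(=O)c3ccccc3)nc3cc(-c4ccccc4)nn23)cc(OC)c1OC` gives 34300 nM. The steps of a 1.4-fold higher number from compound 1 to compound 2 (0.14 log units; within the scatter), a 1.8-fold higher number from compound 1 to compound 3 (0.25 log units; within the scatter) and a 1.3-fold higher number from compound 2 to compound 3 (0.10 log units; within the scatter) all stay within the scatter, so the three measured compounds cannot be told apart. Compound 4 `COc1ccc(/C=C/C(=O)c2cc(-c3cc(OC)c(OC)c(OC)c3)n3nc(-c4ccccc4)cc3n2)cc1OC` differs from compound 1 by 3,4-dimethoxyphenyl in place of 4-chlorophenyl on a double-bonded chain carbon bound to a double-bonded chain carbon. Among the measured compounds shown here, none of the measured steps makes this kind of change, and those that exist moved the numbers little. The expected step of a 1.0-fold higher number from compound 1 to compound 4 (0.01 log units; within the scatter) is therefore none beyond the scatter. Compound 4 is estimated at 20000 nM, with a range from 7000 nM to 60000 nM.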

Compound 4, half-maximal inhibitory concentration: 15300 nM
For compound 4 the middle estimate is 1.3-fold (0.12 log units) above the measured one; low and high end bracket the measured number.
By their numbers in this assay, from the lowest: compounds 4, 1, 2 and 3 (each within the scatter of the next, the first and the last beyond it).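

Replacing 4-chlorophenyl with 3,4-dimethoxyphenyl gives a 1.3-fold lower number from compound 1 to compound 4 (0.11 log units; within the scatter) in this assay. At this place, on a double-bonded chain carbon bound to a double-bonded chain carbon, a ring with two methoxy groups and a ring with one chlorine therefore cannot be told apart, even though the new group brings more heavy atoms and two hydrogen-bond acceptors. No measurement shown here explains this result. From the compounds shown here alone, it remains open whether a single methoxy group would give a similar number, and whether an amine or a carboxylic acid on this ring would move it beyond the scatter.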